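Trifluoromethoxy for Trifluoromethyl on a Second Core

A few compounds are considered here, and "the series" means these few. Any claim that something is new, unique, unknown or untested is made for them only; others in the source may bear on it.

Compound 1 `Oc1cccc2[nH]c(-c3ccc(-c4ccc(-c5ccc(C(F)(F)F)cc5)cc4)cc3)nc12` and compound 2 `Oc1cccc2[nH]c(-c3ccc(-c4ccc(-c5ccc(OC(F)(F)F)cc5)cc4)cc3)nc12` share one core and differ only by trifluoromethoxy in place of trifluoromethyl on an aromatic carbon. In a functional assay on ZR-75-1 cells (Homo sapiens) for inhibition, read by sulforhodamine B assay (on this read-out lower numbers stand for stronger inhibition of growth and higher numbers for weaker inhibition of growth), compound 1 gives 5110 nM, and compound 2 gives 3800 nM; this amounts to a 1.3-fold lower number from compound 1 to compound 2 (0.13 log units; within the scatter). Compound 3 `Cc1ccc2[nH]c(-c3ccc(-c4ccc(-c5ccc(C(F)(F)F)cc5)cc4)cc3)nc2c1` carries a different core, the difference from compound 1 being (5-methyl-1H-benzimidazol-2-yl in place of 4-hydroxy-1H-benzimidazol-2-yl on an aromatic carbon). In this assay compound 3 gives 2410 nM, which is a 2.1-fold lower number from compound 1 to compound 3 (0.33 log units; beyond the scatter). Compound 4 `Cc1ccc2[nH]c(-c3ccc(-c4ccc(-c5ccc(OC(F)(F)F)cc5)cc4)cc3)nc2c1` has not yet been measured and differs from compound 3 by trifluoromethoxy in place of trifluoromethyl on an aromatic carbon, the same change as that from compound 1 to compound 2, at a place described in the same words. Because a 1.3-fold lower number from compound 1 to compound 2 (0.13 log units; within the scatter) stayed within the scatter, the corresponding move for compound 4 in this assay is expected to be small, a 1.3-fold lower number from compound 3 to compound 4 (0.10 log units; within the scatter). Compound 4 is therefore estimated at 1900 nM, with a likely range from 900 nM to 4000 nM.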

Compound 4, concentration for 50% growth inhibition: 2410 nM
For compound 4 the middle estimate is 1.3-fold (0.10 log units) below the measured one; low and high end bracket the measured number.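

In this assay, trifluoromethoxy in place of trifluoromethyl on the core of compound 3 gives no change at the digits printed from compound 3 to compound 4 (within the scatter), and this step reads alike on the two cores: the same change on two cores in this assay, a 1.3-fold lower number (0.13 log units; within the scatter) from compound 1 to compound 2 and no change at the digits printed (within the scatter) from compound 3 to compound 4, 1.3-fold (0.13 log units) apart, within the scatter of two such steps

With trifluoromethoxy in place, the change of core gives a 1.6-fold lower number from compound 2 to compound 4 (0.20 log units; within the scatter), and this step also reads alike in both settings: the same change on two cores in this assay, a 2.1-fold lower number (0.33 log units; beyond the scatter) from compound 1 to compound 3 and a 1.6-fold lower number (0.20 log units; within the scatter) from compound 2 to compound 4, 1.3-fold (0.13 log units) apart, within the scatter of two such steps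

The trifluoromethoxy steps both lie within the scatter, so the agreement is between two small steps, and these four compounds do not show that the change would stay small on any other core.

The compounds shown leave open how an amine or a carboxylic acid in place of trifluoromethoxy would read. They also leave open how the trifluoromethoxy change would read on a core carrying a longer chain in place of the methyl.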